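Methoxy pattern on the aryl ring of the acrylic acid

A few compounds are considered here, and "the series" means these few. Any claim that something is new, unique, unknown or untested is made for them only; others in the source may bear on it.

Measured compounds:
Compound 1, `CC(=O)n1cc(/C=C(/C(=O)O)c2ccccc2)c2cc(OCc3ccccc3)ccc21`: 57500 nM
Compound 2, `COc1cc(OC)cc(/C(=C\c2cn(C(C)=O)c3ccc(OCc4ccccc4)cc23)C(=O)O)c1`: 26000 nM

In a functional assay on A549 cells (Homo sapiens) for cytotoxicity, read by MTT assay, with a stated time of 72 h (a higher number here means a weaker inhibitor, a lower number a stronger inhibitor), compound 2 holds the lower of the two numbers, with compound 1 giving 57500 nM as its only comparator. Among the compounds with values here, the one measured step, a 2.2-fold lower number from compound 1 to compound 2 (0.34 log units; beyond the scatter), arose from 3,5-dimethoxyphenyl in place of phenyl on a double-bonded chain carbon bound to a carbonyl carbon and a double-bonded chain carbon. Compound 3, `COc1ccc(/C(=C\c2cn(C(C)=O)c3ccc(OCc4ccccc4)cc23)C(=O)O)cc1`, has not been measured in this assay. It differs from compound 2 by 4-methoxyphenyl in place of 3,5-dimethoxyphenyl on a double-bonded chain carbon bound to a carbonyl carbon and a double-bonded chain carbon. Within the data shown here, no measured step covers this exact swap; the only step available shows that adding methoxy groups to the phenyl lowered the number, and compound 3 keeps one methoxy group but at a different substitution pattern. A number between those of compound 1 and compound 2 is therefore expected, with the step of a 1.5-fold higher number from compound 2 to compound 3 (0.16 log units; within the scatter) not clearly beyond the scatter. For compound 3 the estimate is 38000 nM, within 15000 nM to 90000 nM.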

Compound 3, half-maximal inhibitory concentration: > 100000 nM
Compound 3 gave a limit, no number; the forecaster's own chance of this, stated with the estimate: 10%; middle value at least 2.6-fold (0.42 log units) from the limit.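

Compound 3 gave a limit, not a number, in this assay: the limit of > 100000 nM in this assay, at which 1 of the 3 values shown sits.

On the double-bonded chain carbon bound to a carbonyl carbon and a double-bonded chain carbon, 4-methoxyphenyl in place of 3,5-dimethoxyphenyl gives an at least 3.8-fold higher number from compound 2 to compound 3 (0.58 log units; beyond the scatter), so the methoxy pattern at this position matters, and not merely the presence of a methoxy group. Methoxy in place of hydrogen on an aromatic carbon gives an at least 1.7-fold higher number from compound 1 to compound 3 (0.24 log units; that floor lies within the scatter), so a methoxy group on the phenyl does not by itself lower the number, which the earlier step alone could have suggested.

As far as these compounds go, what stays open is whether the lower number of compound 2 depends on methoxy as such, or would persist with ethoxy groups or fluorine atoms in the same places. From the compounds shown here alone, the full size of both new steps also remains unknown, since compound 3 has only a limit.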